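Removing the bromoacrylamide: a matched pair predicts the next

A few compounds are considered here, and "the series" means these few. Any claim that something is new, unique, unknown or untested is made for them only; others in the source may bear on it.

Four chalcone-type compounds are compared here. Compound 1 `C=C(Br)C(=O)Nc1ccc(/C=C/C(=O)c2ccc(Cl)cc2)cc1` and compound 2 `C=C(Br)C(=O)Nc1ccc(/C=C/C(=O)c2cc(OC)c(OC)c(OC)c2)cc1` both carry a (1-bromoethenyl)carbonyl group on the aniline nitrogen; compound 3 `Nc1ccc(/C=C/C(=O)c2ccc(Cl)cc2)cc1` and compound 4 `COc1cc(C(=O)/C=C/c2ccc(N)cc2)cc(OC)c1OC` carry a free amino group in its place. In a functional assay on HeLa cells (Homo sapiens) for antiproliferative activity, with a stated time of 48 h (on this read-out higher numbers stand for weaker inhibition and lower numbers for stronger inhibition), compound 1 gives 1600 nM, compound 2 gives 1100 nM and compound 3 gives 43000 nM; compound 4 has not yet been measured.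

How the cores of compound 1 and compound 2 differ is not broken down here. Between compound 1 and compound 2 the numbers lie within the usual scatter, so no order is drawn between them, whereas compound 3 gives a clearly higher number than either.

The change from compound 1 to compound 3 is hydrogen in place of (1-bromoethenyl)carbonyl on a nitrogen on an aromatic ring, and it produced a 27-fold higher number from compound 1 to compound 3 (1.43 log units; beyond the scatter). The change from compound 2 to compound 4 is hydrogen in place of (1-bromoethenyl)carbonyl on a nitrogen on an aromatic ring, the same change on the same kind of nitrogen; the two differ only in which core carries it.

Because a 27-fold higher number from compound 1 to compound 3 (1.43 log units; beyond the scatter) was large on the core of compound 1, a step of similar size is expected on the core of compound 2, and the estimated step is a 27-fold higher number from compound 2 to compound 4 (1.44 log units; beyond the scatter). Compound 4 is therefore expected to give about 30000 nM in this assay, with a likely range from 10000 nM to 90000 nM. This expectation rests on a single measured pair and the assumption that the two cores respond alike.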

Compound 4, half-maximal inhibitory concentration: 1900 nM
Compound 4: middle estimate off by 16-fold (1.20 log units), on the high side, and the stated range ends above it.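

In this assay, replacing (1-bromoethenyl)carbonyl with hydrogen on the core of compound 2 gave a 1.7-fold higher number from compound 2 to compound 4 (0.24 log units; within the scatter) and so, on this core, the change cannot be told apart from repeat-measurement noise. The step therefore did not carry over in size from the core of compound 1, where the same replacement had a large effect: the same change on two cores in this assay, a 27-fold higher number (1.43 log units; beyond the scatter) from compound 1 to compound 3 and a 1.7-fold higher number (0.24 log units; within the scatter) from compound 2 to compound 4, 16-fold (1.19 log units) apart, beyond the scatter of two such steps. Within the data shown here, this shows that the size of the step cannot be taken from one core to the other, and that a single matched pair is a poor guide here, but with only two pairs it does not show why the cores part or how a third core would respond, and it gives no general rule on whether the (1-bromoethenyl)carbonyl group is needed.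

The compounds shown leave open which part of the group matters on the core of compound 1: the bromine, the double bond or the amide as a whole. An acetyl group or a prop-2-enoyl group without bromine on the same nitrogen, set on both cores, would separate these parts and show whether the two cores still diverge.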